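Branching the Acyl Chain: From Propanoyl to Isopropylcarbonyl

The source may report more compounds than this note shows. Statements on the series, on what has been measured and on what is new or still open speak of the compounds shown alone.

For the measured compounds named here, compound 2 `CCC(=O)N(Cc1ccc(OC)c(O)c1)c1cc(OC)c(OC)c(OC)c1` is the stronger of the two compounds measured so far. In a functional assay on HCT-116 cells (Homo sapiens) for inhibition, read by MTT assay, with a stated time of 48 h (on this read-out higher numbers stand for weaker inhibition and lower numbers for stronger inhibition), compound 2 gives 61 nM, which is the lowest of the two numbers. Going by the values given here, the only neighbour, compound 1 `C#CC(=O)N(Cc1ccc(OC)c(O)c1)c1cc(OC)c(OC)c(OC)c1`, gives 310 nM in this assay, and the step of a 5.1-fold lower number from compound 1 to compound 2 (0.71 log units; beyond the scatter) is the single measured comparison available.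

Compound 3 `COc1ccc(CN(C(=O)C(C)C)c2cc(OC)c(OC)c(OC)c2)cc1O` differs from compound 2 by methyl in place of hydrogen on a saturated chain carbon bound to a carbonyl carbon and a saturated chain carbon. This change also sits on the acyl side of the amide, but it adds branching rather than exchanging an unsaturated group for a saturated one, so the measured step from compound 1 to compound 2 bears on it only loosely. Among the compounds with values here, with no direct precedent, no change beyond the scatter is expected, though a slight weakening remains possible. The estimated step is a 1.4-fold higher number from compound 2 to compound 3 (0.14 log units; within the scatter). Compound 3 is therefore expected to give 85 nM in this assay, within a range of 30 nM to 250 nM.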

Compound 3, half-maximal inhibitory concentration: 310 nM
Estimate against measurement, compound 3: 3.6-fold (0.56 log units) below; measured number above the stated range.
By their numbers in this assay, from the lowest: compound 2; then compounds 1 and 3 (each within the scatter of the next).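

Adding a single methyl to turn propanoyl into isopropylcarbonyl gives a 5.1-fold higher number from compound 2 to compound 3 (0.71 log units; beyond the scatter) in this assay, so this acyl group is sensitive to branching on the saturated chain carbon bound to the carbonyl carbon, and not only to the exchange of ethynyl for ethyl seen earlier. Two quite different groups, ethynyl and isopropyl, show no change at the digits printed from compound 1 to compound 3 (within the scatter) here, which leaves propanoyl as the only one of the three acyl groups that stands apart, with compound 2 the most potent of the set. Nothing measured here explains why the added methyl has this effect.

The compounds shown leave open whether a longer straight chain such as butanoyl would behave like propanoyl or like isopropylcarbonyl. From the compounds shown here alone, it is also open how a smaller acetyl group or a cyclopropyl group on the carbonyl carbon would compare.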